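Unbound share from compound 2 to compound 3

The source may report more compounds than this note shows. Statements on the series, on what has been measured and on what is new or still open speak of the compounds shown alone.

In an ADME assay on a cell-free system (plasma, Homo sapiens) (a higher number here means a larger unbound share of the compound, a lower number a smaller unbound share), compound 1 (`CCc1c(CN(C)CC(=O)O)cccc1-c1nsc(-c2ccc(OC(C)C)c(C(F)(F)F)c2)n1`) gives 0.0049, while compound 2 (`CCc1c(CN(C)C(C)(C)C(=O)O)cccc1-c1nsc(-c2ccc(OC(C)C)c(C(F)(F)F)c2)n1`) gives 0.00004, the lower of the two numbers available. Still unmeasured is compound 3 (`CCc1c(CCCC(=O)O)cccc1-c1nsc(-c2ccc(OC(C)C)c(C(F)(F)F)c2)n1`), which keeps the shared core but has 2-carboxyethyl in place of (1-carboxy-1-methylethyl)(methyl)amino on a saturated chain carbon bound to an aromatic carbon.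

Among the measured compounds shown here, only one measured step bears on this change: a 120-fold lower number from compound 1 to compound 2 (2.09 log units; beyond the scatter), a large step beyond the scatter, with 1-carboxy-1-methylethyl in place of carboxymethyl on an amine nitrogen. It shows that the number can move strongly with the group on that nitrogen. For the measured compounds named here, compound 3 carries neither group and no amine nitrogen, so no measured step covers the change directly. With compound 2 at 0.00004 and the only other reference, compound 1, at 0.0049, a rise that stops short of compound 1 seems most likely. The estimated change is a 25-fold higher number from compound 2 to compound 3 (1.40 log units; beyond the scatter), a large expected rise. For compound 3 the expected unbound fraction is 0.001, with an estimated range from 0.0002 to 0.005.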

Compound 3, unbound fraction: 0.00014
Beside the measured number, compound 3's estimate is 7.1-fold (0.85 log units) above it; measured number below the stated range.
By their numbers in this assay, from the lowest: compound 2; then compound 3; then compound 1.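

In this assay, replacing the whole (1-carboxy-1-methylethyl)(methyl)amino group with a chain that ends in the same carboxylic acid but has no amine nitrogen gives a 3.5-fold higher number from compound 2 to compound 3 (0.54 log units; beyond the scatter), a modest rise that leaves compound 3 much nearer to compound 2 than to compound 1. Measured against the carboxymethyl amine, the same chain gives a 35-fold lower number from compound 1 to compound 3 (1.54 log units; beyond the scatter), so among these three compounds a very small unbound share does not depend on the 1-carboxy-1-methylethyl group, since compound 3 lacks that group and still lies far below compound 1; the higher number of compound 1 therefore belongs to the (carboxymethyl)(methyl)amino arrangement alone. Nothing at hand gives a measured reason for either step.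

Compound 3 differs from compound 1 in both the amine nitrogen and the make-up of the chain, so the share of each in the step remains unresolved; an ether oxygen in the chain in place of that nitrogen would separate them. As far as these compounds go, it also remains open whether a longer chain ending in a carboxylic acid, or an amine chain ending in a primary amide instead of the acid, would lie nearer to compound 1 or to compound 2.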